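Swapping Amino for Phenyl at the Carbonyl of Compound 2

The source may hold more compounds than are shown below. What is called first, only, known or untested is meant among the compounds shown, and "the series" means these compounds.

Compound 1, `O=CN1CCN(c2ccc(Cl)cc2)C1=S`: 12700 nM
Compound 2, `N#C/C(=C\N1CCN(C(=O)c2ccco2)C1=S)C(N)=O`: 7500 nM
Compound 3, `O=CN1CCN(c2cc(Cl)cc(Cl)c2)C1=S`: 14400 nM

Of the compounds shown here, three have so far been measured in a functional assay on KM12 cells (Homo sapiens) for inhibition, read by sulforhodamine B assay, with a stated time of 48 h; a lower number here means a stronger inhibitor of growth, a higher number a weaker inhibitor of growth. Compound 2 has the smallest number of the three, yet its gaps to compound 1 and to compound 3 both fall within the usual scatter, so no real ordering among them can be claimed. Compound 4, `N#C/C(=C\N1CCN(C(=O)c2ccco2)C1=S)C(=O)c1ccccc1`, has not yet been tested. It differs from compound 2 in a single place: phenyl in place of amino on a carbonyl carbon. Going by the values given here, no pair of measured compounds shows what such a change does, so the expectation rests on the structural change alone. A step of no size beyond the scatter is expected, and the step of a 1.3-fold lower number from compound 2 to compound 4 (0.10 log units; within the scatter) is an estimate without measured precedent. Compound 4 is expected to give about 6000 nM, within a range from 1500 nM to 25000 nM.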

Compound 4, concentration for 50% growth inhibition: 6500 nM
Compound 4: the middle estimate sits 1.1-fold (0.03 log units) below what was measured; the measured number falls inside the stated range.
By their numbers in this assay, from the lowest: compounds 4, 2, 1 and 3 (each within the scatter of the next, the first and the last beyond it).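

In this assay, phenyl in place of amino on this carbonyl carbon, the change from carbamoyl to benzoyl, gives a 1.2-fold lower number from compound 2 to compound 4 (0.06 log units; within the scatter). This is the first one-place comparison among these compounds. It shows that this position takes a much larger six-membered aromatic ring, with the amino hydrogen-bond donor gone, without a step beyond the scatter.

As far as these compounds go, whether a methyl group, a dimethylamino group or a carboxylic acid at the same place would also stay within the scatter remains open. Nothing available explains why amino and phenyl read alike here.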